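The compounds below may be only part of what the source reports. "The series", "measured", "known", "first", "only" and "open" are said of these compounds alone.

Compound 1 `O=C(NC(=S)NCc1ccc(C(F)(F)F)cc1)c1ccccc1` is recorded in an assay on isolated protein for inhibition of histone deacetylase 11 (Homo sapiens), read by fluorescence, tested at 100 uM (a higher number here means more inhibition at the concentration tested (going by the name of the read-out), a lower number less inhibition), as "not active" (no number reported), so no single number places it on the scale. Compound 2 `COc1cc(NC(=S)NC(=O)c2ccccc2)cc(OC)c1` in this assay gives 10%. The step to compound 3 `O=C(NC(=S)NCc1ccc(-c2ccccc2)cc1)c1ccccc1` is phenyl in place of trifluoromethyl on an aromatic carbon. Nothing measured here shows how phenyl in place of trifluoromethyl shifts this assay; with compound 1 reported as not active and compound 2 giving 10%, no step beyond the scatter is expected in either direction. Compound 3 is estimated to give 5% in this assay, with a range from -10% to 20%.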

Compound 3, a percentage reported as inhibition, at one concentration (the size of the read-out at that concentration, not a potency): 10%
The estimate for compound 3 lay 5 percentage points below the measured number; the range from low to high includes it.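

No step can be read between compound 1 and compound 3: compound 1 carries no single number. In this assay, on these data alone, it stays open how phenyl in place of trifluoromethyl shifts the read-out. No measurement at hand offers an explanation of the result.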